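This account rests on a few compounds, and the source may have more. Where it says the series, first, only, none or still open, it means among the compounds named here.

Measured in a functional assay on PC-3 cells (Homo sapiens) for inhibition, read by MTT assay, with a stated time of 72 h; a higher number here means a weaker inhibitor, a lower number a stronger inhibitor:

compound 1 `CC(C)(C)OC(=O)N1CCN(C(=S)SCc2cn(-c3ccccc3F)nn2)CC1`: > 128000 nM
compound 2 `CC(C)(C)OC(=O)N1CCN(C(=S)SCc2cn(Cc3ccc(Cl)cc3)nn2)CC1`: > 128000 nM
compound 3 `Cc1ccc(Cn2cc(CSC(=S)N3CCN(C(=O)OCc4ccccc4)CC3)nn2)cc1`: > 128000 nM

Each of these three values is a limit of the assay, not a number. Compound 3 stands at that limit, and the two further values shown sit at the same limit, so no order among the three can be read. Within the data shown here, the only one-place step available, a step that the two limits leave unreadable from compound 1 to compound 2, is left unreadable by the two limits on either side; it is a 4-chlorobenzyl in place of 2-fluorophenyl on an aromatic nitrogen, and it touches neither of the positions that matter for compound 4. The whole of the evidence on the measured set is the limit of > 128000 nM in this assay, at which 3 of the 3 values shown sit.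

Compound 4 `Cc1ccc(Cn2cc(CSC(=S)N3CCN(C(=O)OC(C)(C)C)CC3)nn2)cc1` differs from compound 3 by tert-butyl in place of benzyl on an oxygen next to a carbonyl group. Among the measured compounds shown here, no measured step bears on this change, so there is no size or direction to carry over; the three shared limits are all that is known. The expectation for compound 4 in this assay is therefore that it also stays at the limit, which as an estimated step reads a step that the limit leaves unreadable from compound 3 to compound 4. Compound 4 is expected to give about 150000 nM, within the range 60000 nM to 400000 nM, most likely reported only as a limit.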

Compound 4, half-maximal inhibitory concentration: 17300 nM
Compound 4: the middle estimate sits 8.7-fold (0.94 log units) above what was measured; measured number below the stated range.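

In this assay, tert-butyl in place of benzyl on an oxygen next to a carbonyl group gives an at least 7.3-fold lower number from compound 3 to compound 4 (0.86 log units; beyond the scatter), so this position can take the read-out off the limit. Methyl in place of chloro on an aromatic carbon gives an at least 7.3-fold lower number from compound 2 to compound 4 (0.86 log units; beyond the scatter), and a change of the group on an aromatic nitrogen gives an at least 7.3-fold lower number from compound 1 to compound 4 (0.86 log units; beyond the scatter), so the group on the triazole-side nitrogen counts as well, and not the tert-butoxycarbonyl end alone. Neither end suffices by itself, since compound 1 and compound 2 carry tert-butoxycarbonyl, compound 3 carries 4-methylbenzyl, and only compound 4, with both, gives a number rather than the shared limit: the limit of > 128000 nM in this assay, at which 3 of the 4 values shown sit.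

Steps among the three compounds at the limit cannot be read, and each step to compound 4 gives only a minimum size, as it starts from a limit. Still open, going by these compounds, is how the read-out responds to an isopropyl or cyclohexyl on that oxygen, to a free amine in place of the tert-butoxycarbonyl, or to a 4-methoxybenzyl on the aromatic nitrogen.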